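The source may report more compounds than this note shows. Statements on the series, on what has been measured and on what is new or still open speak of the compounds shown alone.

Working notes on the series.

For the measured compounds named here, compound 1 `CC1CC(C)CN(c2nc(Nc3ccc(C#N)c(C(F)(F)F)c3)nc(Oc3ccnc4ccccc34)n2)C1` is the one member with a numerical read-out: in a functional assay on DU-145 cells (Homo sapiens) for cytotoxicity, read by sulforhodamine B assay, with a stated time of 48 h (on this read-out lower numbers stand for stronger inhibition of growth and higher numbers for weaker inhibition of growth), compound 1 gives 68000 nM. Compound 2 `CN1CCN(c2nc(Nc3ccc(C#N)c(C(F)(F)F)c3)nc(Oc3ccnc4ccccc34)n2)CC1` carries a 4-methylpiperazin-1-yl group on the shared core. In this assay compound 2 reaches only the limit > 100000 nM. The step of an at least 1.4-fold higher number from compound 1 to compound 2 (0.16 log units; that floor lies within the scatter) is therefore a floor rather than a number. Compound 3 `COc1ccc(CN2CCN(c3nc(Nc4ccc(C#N)c(C(F)(F)F)c4)nc(Oc4ccnc5ccccc45)n3)CC2)c(OC)c1OC` has a 2,3,4-trimethoxyphenyl on a saturated chain carbon bound to the ring amine nitrogen. In this assay compound 3 also reaches only the limit > 100000 nM. The step that the two limits leave unreadable from compound 2 to compound 3 cannot be sized, since (the limit of > 100000 nM in this assay, at which 2 of the 3 values shown sit).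

Compound 4 `COc1ccc(N2CCN(c3nc(Nc4ccc(C#N)c(C(F)(F)F)c4)nc(Oc4ccnc5ccccc45)n3)CC2)cc1` is unmeasured; it differs from compound 2 as follows: 4-methoxyphenyl in place of methyl on an amine nitrogen in a ring. The two changes at this nitrogen so far, to compound 2 and to compound 3, both end at the same limit, so no readable step exists to carry over. The expectation for compound 4 in this assay is a value no better than the limit, and the step that the limit leaves unreadable from compound 2 to compound 4 is estimated as within the scatter. Compound 4 is expected near 120000 nM, within 40000 nM to 400000 nM.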

Compound 4, concentration for total growth inhibition: > 100000 nM
Compound 4: a limit, no number; the forecaster's own chance of this, stated with the estimate: 75%; the middle value is on the limit's open side.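

In this assay no new step can be read between compound 2 and compound 4, as each gives only a limit and no number: the limit of > 100000 nM in this assay, at which 3 of the 4 values shown sit.

The compounds shown leave open how far compound 2, compound 3 and compound 4 truly differ from one another in this assay.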